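Swapping Ethyl for Bromo at the Aryl Ring

A few compounds are considered here, and "the series" means these few. Any claim that something is new, unique, unknown or untested is made for them only; others in the source may bear on it.

Compound 1, `FC(F)(F)c1ccccc1-c1nc(NCc2ccccc2)c2ccccc2n1`: 3100 nM
Compound 2, `FC(F)(F)c1ccccc1-c1nc(NCc2ccc(Cl)c(Cl)c2)c2ccccc2n1`: 10400 nM
Compound 3, `CCc1ccccc1-c1nc(NCc2ccc(-c3cccnc3)cc2)c2ccccc2n1`: 780 nM

In an assay on a protein complex for inhibition of ubiquitin carboxyl-terminal hydrolase 1/WD repeat-containing protein 48 (Homo sapiens), read by fluorescence (a higher number here means a weaker inhibitor, a lower number a stronger inhibitor), compound 3 gives the lowest number of the three, and its distance from compound 1 and from compound 2 lies beyond the scatter. Compound 4, `Brc1ccccc1-c1nc(NCc2ccc(-c3cccnc3)cc2)c2ccccc2n1`, differs from compound 3 by bromo in place of ethyl on an aromatic carbon. Among the compounds with values here, the only measured step, a 3.4-fold higher number from compound 1 to compound 2 (0.53 log units; beyond the scatter), concerns the other end of the molecule and does not bear on this change. Compounds 1 and 2 carry a trifluoromethyl group where compound 3 carries ethyl, but they differ elsewhere too, so they offer no clean comparison. The expected step is therefore small, a 1.2-fold higher number from compound 3 to compound 4 (0.06 log units; within the scatter), within the scatter. For compound 4 the estimate is 900 nM, with a range from 350 nM to 2500 nM.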

Compound 4, half-maximal inhibitory concentration: 1600 nM
Beside the measured number, compound 4's estimate is 1.8-fold (0.25 log units) below it; measured number inside the range.
By their numbers in this assay, from the lowest: compound 3; then compounds 4 and 1 (each within the scatter of the next); then compound 2.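

With everything else in the molecule held the same, this aromatic carbon proves sensitive to its substituent: in this assay, bromo in place of ethyl gives a 2.1-fold higher number from compound 3 to compound 4 (0.31 log units; beyond the scatter), so the step is modest but real. The 2-ethylphenyl group thus gives the lower number of these two, and the two groups are not interchangeable here. No available data explain this difference.

Going by these compounds, it remains open how a methoxy group or a chloro group would behave at this carbon. Also open, on these data alone, is how trifluoromethyl would compare with ethyl and bromo on the rest of compound 3.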